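Adding a Third Chloro Group to Compound 3

The source may hold more compounds than are shown below. What is called first, only, known or untested is meant among the compounds shown, and "the series" means these compounds.

Compound 1, `O=C1C[C@H](O)CC(CCc2cccc3ccccc23)O1`: 81000 nM
Compound 2, `O=C1C[C@H](O)C[C@@H](/C=C/c2ccc(Br)c3ccccc23)O1`: 4000 nM
Compound 3, `O=C1C[C@H](O)CC(CCc2ccc(Cl)c3cc(Cl)ccc23)O1`: 7000 nM

Of the compounds shown here, three have been measured in an assay on isolated protein for inhibition of 3-hydroxy-3-methylglutaryl-coenzyme A reductase (Rattus norvegicus); on this read-out higher numbers stand for weaker inhibition and lower numbers for stronger inhibition. Compound 3 stands second highest of the three numbers; its nearest neighbour is compound 2, whose number is lower by an amount within the usual scatter, while compound 1 lies furthest away, with a number higher by an amount beyond the scatter. Compound 4, `O=C1C[C@H](O)CC(CCc2c(Cl)cc(Cl)c3cc(Cl)ccc23)O1`, has not yet been measured. It differs from compound 3 by chloro in place of hydrogen on an aromatic carbon. For the measured compounds named here, no two measured compounds differ in just one place, so no single step guides this change, and only a small step, if any, is expected in this assay. The estimate for compound 4 is 5000 nM, with a range from 1500 nM to 20000 nM. That estimate amounts to an expected step of a 1.4-fold lower number from compound 3 to compound 4 (0.15 log units; within the scatter), within the scatter.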

Compound 4, half-maximal inhibitory concentration: 33 nM
Estimate against measurement, compound 4: 150-fold (2.18 log units) above, outside the stated range (below it).
By their numbers in this assay, from the lowest: compound 4; then compounds 2 and 3 (each within the scatter of the next); then compound 1.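

On this assay a single chloro in place of hydrogen on an aromatic carbon, ortho to a large group and meta to a chloro group, brings a 210-fold lower number from compound 3 to compound 4 (2.33 log units; beyond the scatter) and so shows that this one position can carry a large change. The earlier compounds shown here could not show this, since no two of them differed in just one place. Nothing measured here explains the size of the step.

On these data alone, whether a fluoro, methyl or methoxy group at this position would give a similar step remains open. So does whether chloro here would do the same in compound 1 or compound 2.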